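The source may report more compounds than this note shows. Statements on the series, on what has been measured and on what is new or still open speak of the compounds shown alone.

For the measured compounds named here, the three compounds measured so far share one core and differ only in the linker that joins its two parts. Compound 1 `CSc1nc(NCCCNc2ccnc3cc(Cl)ccc23)c(C#N)c(-c2ccccc2)n1` carries a shorter chain attached through an amine, compound 2 `CSc1nc(NCCCCNc2ccnc3cc(Cl)ccc23)c(C#N)c(-c2ccccc2)n1` a longer chain attached the same way, and compound 3 `CSc1nc(OCCCNc2ccnc3cc(Cl)ccc23)c(C#N)c(-c2ccccc2)n1` a chain attached through an oxygen instead. In an ADME assay on HeLa cells (Homo sapiens) for inhibition, read by cell counting (a lower number here means a stronger inhibitor, a higher number a weaker inhibitor), compound 1 gives 11000 nM, compound 2 gives 8500 nM, and compound 3 gives 3400 nM. Compound 2 thus stands second highest of the three numbers; its nearest neighbour is compound 1, whose value lies within the usual scatter of repeated measurements, while compound 3 lies beyond that scatter at a lower number.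

Compound 4 `CSc1nc(NCCCCNc2ccnc3cc(Cl)ccc23)c(C#N)c(-c2cccc([N+](=O)[O-])c2)n1` keeps the longer amine-linked chain of compound 2 and changes the phenyl group: nitro in place of hydrogen on an aromatic carbon. Going by the values given here, no pair among the measured compounds probes a change on that ring, so nothing measured here speaks for or against a shift. With the change away from the part that varies among the measured compounds, the step from compound 2 to compound 4 is expected to be small, most likely none beyond the scatter, as a 1.2-fold lower number from compound 2 to compound 4 (0.08 log units; within the scatter). Compound 4 is therefore estimated at 7000 nM in this assay, with a likely range from 2500 nM to 20000 nM.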

Compound 4, half-maximal inhibitory concentration: 1100 nM
Beside the measured number, compound 4's estimate is 6.4-fold (0.80 log units) above it; measured number outside the range, below it.
By their numbers in this assay, from the lowest: compound 4; then compound 3; then compounds 2 and 1 (each within the scatter of the next).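

The phenyl ring is not a silent part of these molecules: in this assay, putting a nitro group on it gives a 7.7-fold lower number from compound 2 to compound 4 (0.89 log units; beyond the scatter) and this step lies beyond the scatter of repeated measurements. For the compounds shown here, the earlier compounds differ only in the linker, so this is the first sign that the number also responds to a change on the aromatic ring, here at a carbon meta to a large group, with the chain left as it is in compound 2. Nothing available here accounts for the step from phenyl to 3-nitrophenyl, which stands as an observation only.

A single step cannot tell whether the nitro group in particular matters, or whether another group at this place, such as an amine, a methoxy group or a carboxylic acid, would act the same way. Also open, from the compounds shown here alone, are whether nitro on another carbon of that ring gives a step of similar size, and whether the same change carries over to the shorter amine-linked chain of compound 1 or the oxygen-linked chain of compound 3.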